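This account rests on a few compounds, and the source may have more. Where it says the series, first, only, none or still open, it means among the compounds named here.

Working notes on the series. Compound 1 `Cc1nn(-c2ncnc3nc[nH]c23)c2c1C(OCc1ccc(Cl)cc1Cl)CC(=O)N2` and compound 2 `Cc1nn(-c2ncnc3nc[nH]c23)c2c1C(OCCn1cccn1)CC(=O)N2` share one core and differ only in the side chain. In a functional assay on HEK293 cells for agonist activity at G-protein coupled receptor 39 (Homo sapiens), read by scintillation proximity assay and inositol phosphate accumulation, with a stated time of 75 min, in the presence of a further agent that is not named here (a higher number here means that more compound is needed for the effect, a lower number that less compound is needed), compound 1 gives 4 nM and compound 2 gives 16 nM; compound 2 thus stands highest of the two numbers, with compound 1 as its nearest neighbour. The step of a 4.0-fold higher number from compound 1 to compound 2 (0.60 log units; beyond the scatter) is the only one measured so far.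

Compound 3 `Cc1nn(-c2ncnc3nc[nH]c23)c2c1C(C(=O)N(C)c1ccccc1)CC(=O)N2` is not yet measured; relative to compound 2 the change is methyl(phenyl)carbamoyl in place of 2-(1H-pyrazol-1-yl)ethoxy on a saturated ring carbon. Among the measured compounds shown here, only the step from compound 1 to compound 2 bears on this, and loosely: there a 2,4-dichlorophenyl went with the lower number and the pyrazolyl group with the higher one, while here the oxygen link is also replaced. A modest step toward a lower number is therefore expected, a 2.0-fold lower number from compound 2 to compound 3 (0.30 log units; within the scatter), with wide uncertainty. Compound 3 is estimated at 8 nM, range 2 nM to 40 nM.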

Compound 3, half-maximal effective concentration: 32 nM
The estimate for compound 3 lay 4.0-fold (0.60 log units) below the measured number; the measured number falls inside the stated range.
By their numbers in this assay, from the lowest: compound 1; then compounds 2 and 3 (each within the scatter of the next).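

In this assay, the saturated ring carbon tolerates a side chain with no ether oxygen: methyl(phenyl)carbamoyl in place of 2-(1H-pyrazol-1-yl)ethoxy gives a 2.0-fold higher number from compound 2 to compound 3 (0.30 log units; within the scatter). Against (2,4-dichlorobenzyl)oxy, the same group gives an 8.0-fold higher number from compound 1 to compound 3 (0.90 log units; beyond the scatter), so two side chains with different links and different aromatic rings lie within the scatter of each other, while compound 1 remains apart from both. No measurement available here accounts for these differences.

The compounds shown leave open whether the gap to compound 1 follows the two chlorine atoms or the benzyloxy link, which a plain benzyloxy or a 2,4-dichlorophenyl on the carbamoyl nitrogen would separate. Also open, as far as these compounds go, is what the methyl on that nitrogen contributes, a question for phenylcarbamoyl.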